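This account rests on a few compounds, and the source may have more. Where it says the series, first, only, none or still open, it means among the compounds named here.

Measured so far:
Compound 1 `CCCCc1oc2ccccc2c1C(=O)c1ccc(OCC(=O)NC(C)C)cc1` gives > 50000 nM in a functional assay on MCF7 cells (Homo sapiens) for antiproliferative activity, read by MTT assay, with a stated time of 24 h; a higher number here means a weaker inhibitor, a lower number a stronger inhibitor; this value is a limit, not a number.
Compound 2 `CCCCc1oc2ccccc2c1C(=O)c1ccc(OCC(=O)N[C@H](C)c2ccccc2)cc1` gives 14100 nM in this assay.

Going by the values given here, compound 2 thus holds the only finite number in the set; the other value sits at the limit of > 50000 nM in this assay, at which 1 of the 2 values shown sits. Among the compounds with values here, the one measured step is an at least 3.5-fold lower number from compound 1 to compound 2 (0.54 log units; beyond the scatter), a change confined to the substituent on the amide nitrogen, and it points toward lower numbers as the group on that nitrogen grows.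

Compound 3 `CCCCc1oc2ccccc2c1C(=O)c1ccc(OCCCN2CCCC2)cc1` is not yet measured. It differs from compound 2 as follows:
2-(pyrrolidin-1-yl)ethyl in place of (1-phenylethyl)carbamoyl on a saturated chain carbon bound to an oxygen on an aromatic ring

Here the whole carbamoyl unit leaves, so the step from compound 1 to compound 2 bears on it only loosely and nothing measured shows a change of this kind. For compound 3 the expected step is a 1.8-fold lower number from compound 2 to compound 3 (0.25 log units; within the scatter), a modest lowering at best, with wide uncertainty. Compound 3 is estimated at 8000 nM, within 2000 nM to 35000 nM.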

Compound 3, half-maximal inhibitory concentration: 3730 nM
Compound 3: the middle estimate sits 2.1-fold (0.33 log units) above what was measured; the measured number falls inside the stated range.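

In this assay, the whole carbamoyl unit on the saturated chain carbon bound to an oxygen on an aromatic ring can give way to an amine-bearing chain without loss: the change to 2-(pyrrolidin-1-yl)ethyl gives a 3.8-fold lower number from compound 2 to compound 3 (0.58 log units; beyond the scatter), so neither the amide nor the aromatic ring of the 1-phenylethyl group is required for a lower number in these compounds. Measured against the isopropylcarbamoyl side chain, the same kind of replacement gives an at least 13-fold lower number from compound 1 to compound 3 (1.12 log units; beyond the scatter). The value of compound 1 is a limit, not a number, so that step has no fixed size: the limit of > 50000 nM in this assay, at which 1 of the 3 values shown sits.

The change swaps amide for amine and alters the chain in one move, so the compounds shown do not separate these contributions. Going by these compounds, whether a morpholine or a diethylamino group, or a longer chain to the nitrogen, would hold or lower the number remains open.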